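The source may hold more compounds than are shown below. What is called first, only, known or untested is meant among the compounds shown, and "the series" means these compounds.

Of the compounds shown here, three from this series have been measured in a functional assay on PC-3 cells (Homo sapiens) for antiproliferative activity, read by MTT assay, with a stated time of 72 h; a lower number here means a stronger inhibitor, a higher number a weaker inhibitor. Compound 1 `O=C(COc1ccc(C(=O)/C=C/c2cccc(Cl)c2)cc1)N[C@H]1CCOC1=O` gives 4990 nM. Compound 2 `O=C1OCC[C@@H]1NC(=S)SCCOc1ccccc1` gives > 64000 nM, which is a limit of the assay rather than a number. Compound 3 `Cc1cc(Cl)ccc1NCC(=O)N[C@H]1CCOC1=O` gives > 64000 nM, again a limit and not a number. Compound 3 thus stands at the limit of > 64000 nM in this assay, at which 2 of the 3 values shown sit, together with compound 2, while compound 1 alone has a numerical value.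

Compound 4 `O=C(CNc1ccc(Cl)cc1)N[C@H]1CCOC1=O` has not yet been measured. It differs from compound 3 in one place: hydrogen in place of methyl on an aromatic carbon, ortho to a large group and meta to a chloro group. Going by the values given here, no measured pair shows what this change does in this assay. With compound 3 sitting at a limit, the step is expected to be none beyond the scatter, and compound 4 is expected to remain near or at the limit as well.

Compound 4 is therefore estimated at 64000 nM, with a range from 20000 nM to 200000 nM. This estimate means an expected step of a number no higher from compound 3 to compound 4 (the limit leaves the size open), within the scatter.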

Compound 4, half-maximal inhibitory concentration: > 64000 nM
Compound 4: no number, only a limit (the forecaster's own chance of this, stated with the estimate: 75%); the middle value sits exactly at the limit.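

Going by these compounds alone, compound 3 and compound 4 each give only a limit of the assay and no number, so no step between them can be read in this assay. That limit recurs among the compounds shown: the limit of > 64000 nM in this assay, at which 3 of the 4 values shown sit. The compounds shown leave open what hydrogen in place of methyl on an aromatic carbon does to antiproliferative activity.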